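An Amino Analogue of Compound 2: Expected Inhibition

The compounds below may be only part of what the source reports. "The series", "measured", "known", "first", "only" and "open" are said of these compounds alone.

Measured compounds:
compound 1 `COc1cc(-c2nccn3cc(-c4ccc(Cl)cc4)nc23)cc(OC)c1OC`, 475 nM
compound 2 `COc1cc(-c2nccn3cc(-c4ccccc4)nc23)cc(OC)c1OC`, 267 nM

In a functional assay on HepG2 cells (Homo sapiens) for inhibition, read by MTT assay, with a stated time of 48 h (on this read-out higher numbers stand for weaker inhibition and lower numbers for stronger inhibition), compound 2 gives 267 nM, the lower of the two numbers shown, although the step of a 1.8-fold lower number from compound 1 to compound 2 (0.25 log units; within the scatter) is within the scatter, so no order between them is claimed. Compound 3 `COc1cc(-c2nccn3cc(-c4ccc(N)cc4)nc23)cc(OC)c1OC` differs from compound 2 by amino in place of hydrogen on an aromatic carbon. For the measured compounds named here, no measured step introduces an amino group, and the only measured step, a 1.8-fold lower number from compound 1 to compound 2 (0.25 log units; within the scatter), is itself within the scatter, so nothing points to a shift. Compound 3 is therefore expected to show no step beyond the scatter, a 1.0-fold lower number from compound 2 to compound 3 (0.01 log units; within the scatter). Compound 3 is estimated in this assay at 260 nM, within 90 nM to 750 nM.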

Compound 3, half-maximal inhibitory concentration: 252 nM
Beside the measured number, compound 3's estimate is 1.0-fold (0.01 log units) above it; the measured number falls inside the stated range.
By their numbers in this assay, from the lowest: compounds 3, 2 and 1 (each within the scatter of the next).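

Amino in place of hydrogen gives a 1.1-fold lower number from compound 2 to compound 3 (0.03 log units; within the scatter) in this assay and amino in place of chloro gives a 1.9-fold lower number from compound 1 to compound 3 (0.28 log units; within the scatter) here, so hydrogen, chloro and amino, para to a large group, all lie within the scatter of one another. This place on the phenyl ring thus takes a group with a hydrogen-bond donor without a step beyond the scatter. Nothing available explains this flat result. Still open, going by these compounds, is whether a carboxylic acid, a dimethylamine or a longer chain at this place would move the number beyond the scatter.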